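Methylcarbamoyl for Carboxy, Repeated on a Second Core

The source may hold more compounds than are shown below. What is called first, only, known or untested is meant among the compounds shown, and "the series" means these compounds.

Of the compounds shown here, three have been tested in a functional assay on KB cells (Homo sapiens) for inhibition, read by sulforhodamine B assay, with a stated time of 72 h (a higher number here means a weaker inhibitor of growth, a lower number a stronger inhibitor of growth), and every one of them sits at a limit. Compound 1 `Cn1ncc2cc(-c3cnccc3/C=C/C(=O)O)ccc21` in this assay gives > 10000 nM, which is a limit of the assay and not a number. Compound 3 `O=C(O)CCc1ccncc1-c1ccc2ccccc2c1` in this assay gives > 10000 nM, again a limit. Compound 2 `CNC(=O)CCc1ccncc1-c1ccc2ccccc2c1` in this assay gives > 10000 nM, also a limit. The change from compound 3 to compound 2 is methylamino in place of hydroxy on a carbonyl carbon, and the step it made is a step that the two limits leave unreadable from compound 3 to compound 2; its size cannot be read because of the limit of > 10000 nM in this assay, at which 3 of the 3 values shown sit.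

Compound 4 `CNC(=O)/C=C/c1ccncc1-c1ccc2c(cnn2C)c1` carries the same kind of change relative to compound 1: methylamino in place of hydroxy on a carbonyl carbon. The place is not identical, though: in compound 3 the carbonyl carbon's other neighbour is a saturated chain carbon, in compound 1 a double-bonded chain carbon. The difference between the two cores is not broken down here.

With nothing but limits to rest on, compound 4 is expected to behave like compound 1, so the step that the limit leaves unreadable from compound 1 to compound 4 is expected to be small. Compound 4 is therefore estimated at 15000 nM, within 4000 nM and 60000 nM.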

Compound 4, concentration for 50% growth inhibition: > 10000 nM
Compound 4: only a limit was reported (the forecaster's own chance of this, stated with the estimate: 80%); the middle value is on the limit's open side.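

In this assay, no step can be read between compound 1 and compound 4, because both values are limits and not numbers: the limit of > 10000 nM in this assay, at which 4 of the 4 values shown sit.

The compounds shown leave open whether methylcarbamoyl in place of carboxy changes growth inhibition at all on either core, and which structural change would give a readable value.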